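A few compounds are considered here, and "the series" means these few. Any claim that something is new, unique, unknown or untested is made for them only; others in the source may bear on it.

Measured in an assay on CHO cells for inhibition of sodium- and chloride-dependent glycine transporter 1 (Homo sapiens); on this read-out higher numbers stand for weaker inhibition and lower numbers for stronger inhibition:
compound 1, `CN(CCC(Oc1ccc(C(F)(F)F)cc1)c1ccc(F)cc1)CC(=O)O`: 251 nM
compound 2, `CN(CCCC(=O)O)CCC(Oc1ccc(C(F)(F)F)cc1)c1ccccc1`: 100000 nM

Compound 1 holds the lower of the two numbers; compound 2 lies far above it, and since the two structures differ in more than one place, only the two values themselves can be read from them. Compound 3 `COc1ccc(C(CCN(C)CC(=O)O)Oc2ccc(C(F)(F)F)cc2)cc1` follows from compound 1 by methoxy in place of fluoro on an aromatic carbon. Going by the values given here, no measured pair shows this change, so no direction is fixed; in this assay a step no larger than the usual scatter, in either direction, is expected. For compound 3 the estimate is 300 nM, range 100 nM to 1000 nM. This corresponds to an expected step of a 1.2-fold higher number from compound 1 to compound 3 (0.08 log units; within the scatter).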

Compound 3, half-maximal inhibitory concentration: 501 nM
Compound 3: the middle estimate sits 1.7-fold (0.22 log units) below what was measured; the range from low to high includes it.
By their numbers in this assay, from the lowest: compounds 1 and 3 (each within the scatter of the next); then compound 2.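

In this assay, going by these compounds alone, the first single-place comparison gives a 2.0-fold higher number from compound 1 to compound 3 (0.30 log units; within the scatter) for methoxy in place of fluoro, on an aromatic carbon para to a large group. At this position, therefore, the read-out does not separate 4-fluorophenyl from 4-methoxyphenyl, although the entering group brings an extra heavy atom and a hydrogen-bond acceptor. Nothing at hand gives a reason for this result.

Open, as far as these compounds go, is whether a chloro group, a hydroxyl or an amine at this position would also stay within the scatter. The separate contributions of the places in which compound 2 differs from compound 1 cannot be read.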